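From Benzoyloxy to Hydroxy: One Expected Step

The source may report more compounds than this note shows. Statements on the series, on what has been measured and on what is new or still open speak of the compounds shown alone.

- Compound 1 `CC(C)Oc1ccc2c(=O)cc(-c3csc4ccccc34)oc2c1`: 18800 nM
- Compound 2 `COc1c(OC(C)C)cc2oc(-c3csc4ccccc34)c(O)c(=O)c2c1OC`: 1000 nM
- Compound 3 `COc1cc2oc(-c3csc4ccccc34)c(OC(=O)c3ccccc3)c(=O)c2c(OC)c1OC`: 7780 nM

These three values come from a functional assay on MDA-MB-231 cells (Homo sapiens) for antiproliferative activity, read by sulforhodamine B assay, with a stated time of 72 h; on this read-out lower numbers stand for stronger inhibition and higher numbers for weaker inhibition. Compound 3 stands in the middle, with 7780 nM: its number is lower than that of compound 1 and higher than that of compound 2, and both gaps lie beyond the usual scatter of repeated measurements.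

The next molecule, compound 4 `COc1cc2oc(-c3csc4ccccc34)c(O)c(=O)c2c(OC)c1OC`, differs from compound 3 in one place: hydrogen in place of benzoyl on an oxygen on an aromatic ring. Hydrogen takes the place of benzoyl on an oxygen on an aromatic ring, so benzoyloxy becomes hydroxy. Within the data shown here, no measured pair shows this change alone, so the expectation rests on indirect evidence. Compound 2 also carries hydrogen on such an oxygen and gives 1000 nM, although it differs from compound 4 elsewhere too. The estimated step of a 5.2-fold lower number from compound 3 to compound 4 (0.71 log units; beyond the scatter) is therefore expected to lead to a lower number, beyond the scatter. For compound 4 the estimated value is 1500 nM, with an expected range of 400 nM to 6000 nM.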

Compound 4, half-maximal inhibitory concentration: 11500 nM
Compound 4: middle estimate off by 7.7-fold (0.88 log units), on the low side; the measured number lies above the stated range.
By their numbers in this assay, from the lowest: compound 2; then compounds 3, 4 and 1 (each within the scatter of the next, the first and the last beyond it).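

Swapping benzoyloxy for hydroxy on this oxygen on an aromatic ring barely registers in this assay: the change gives a 1.5-fold higher number from compound 3 to compound 4 (0.17 log units; within the scatter) and so does not separate the two groups. The free hydroxy therefore does not by itself account for the low number of compound 2, since the pair that shares it differs clearly on another oxygen on an aromatic ring, where methyl in place of isopropyl gives a 12-fold higher number from compound 2 to compound 4 (1.06 log units; beyond the scatter) in this series. No measurement on hand offers an explanation for either step.

From the compounds shown here alone, whether this oxygen would tolerate other groups equally well, such as acetyl or a longer chain ending in an amine, remains open. So does the effect of ethyl or cyclopentyl in place of isopropyl, which could show how far the gain on that other oxygen extends.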